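The source may hold more compounds than are shown below. What is called first, only, known or untested is meant among the compounds shown, and "the series" means these compounds.

Measured so far in an ADME assay on MT4 cells (Homo sapiens) for cytotoxicity, read by spectrophotometry, with a stated time of 5 days; a lower number here means that less compound is tolerated, a higher number that more compound is tolerated:

- compound 1 `O=C1/C(=N\NC(=S)NO)c2cc(F)ccc2N1CN1CCN(c2ccc(Cl)cc2)CC1`: 194000 nM
- compound 2 `CCn1cc(C(=O)O)c(=O)c2cc(F)c(N3CCN(CN4C(=O)/C(=N\NC(=S)NO)c5cc(C)ccc54)CC3)cc21`: 327000 nM
- compound 3 `CONC(=S)N/N=C1\C(=O)N(CN2CCN(c3ccc(Cl)cc3)CC2)c2ccc(Cl)cc21`: 229000 nM

Compound 2 at 327000 nM cannot be separated from compound 3 at 229000 nM or from compound 1 at 194000 nM, since all three values lie within the usual scatter of one another.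

The next compound to be measured is compound 4 `CCn1cc(C(=O)O)c(=O)c2cc(F)c(N3CCN(CN4C(=O)/C(=N\NC(=S)NO)c5cc(F)ccc54)CC3)cc21`. It keeps the structure of compound 2 except for fluoro in place of methyl on an aromatic carbon. Among the compounds with values here, no two measured compounds differ in one place only, so the size of this change has no direct precedent. The nearest indication is indirect: compound 1 carries fluoro on that same aromatic carbon, with a different remainder, and gives 194000 nM, within the scatter of compound 2 at 327000 nM. On that basis, no change beyond the scatter is expected in this assay, in either direction.

The expected step of a 1.2-fold lower number from compound 2 to compound 4 (0.08 log units; within the scatter) is therefore small.

For compound 4 the estimated value is 270000 nM, with an expected range of 140000 nM to 500000 nM.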

Compound 4, half-maximal cytotoxic concentration: 208000 nM
Compound 4: the middle estimate sits 1.3-fold (0.11 log units) above what was measured; the range from low to high includes it.
By their numbers in this assay, from the lowest: compounds 1, 4, 3 and 2 (each within the scatter of the next).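

In this assay this position now has its first direct reading, a 1.6-fold lower number from compound 2 to compound 4 (0.20 log units; within the scatter), so fluoro in place of methyl on this aromatic carbon, meta to a fused ring and para to a fused ring, gives no separable change on the remainder shared by the two compounds. The earlier link rested only on compound 1, which carries fluoro on that same carbon but has a different remainder, whereas this pair holds everything else fixed and isolates the exchange of one heavy atom for another. No measurement shown offers an explanation of this result.

Open, from the compounds shown here alone, is whether this carbon tolerates any group in this assay or only these two small substituents, since a nitrile, a trifluoromethyl group or an amine in the same place could give a step of a different size in this assay. Also open, going by these compounds, is whether the exchange of methyl for fluoro would stay as small on the remainder of compound 1, which is represented here only by its fluoro form.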